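The source may hold more compounds than are shown below. What is called first, only, known or untested is meant among the compounds shown, and "the series" means these compounds.

Values measured in a physicochemical assay for solubility, read by chemiluminescence, measured as kinetic solubility (a lower number here means a less soluble compound, a higher number a more soluble compound), are these.

- Compound 1 `COc1c(F)ccc2c1c(NS(=O)(=O)c1ccc(Cl)s1)nn2Cc1cccc(CNC(=O)C(C)(C)O)c1` gives >= 174 ug/mL as a limit of the assay, not a number.
- Compound 2 `COc1cc(F)cc2c1c(NS(=O)(=O)c1ccc(Cl)s1)nn2Cc1cccc(CNC(C)=O)c1` gives >= 161 ug/mL as a limit of the assay, not a number.
- Compound 3 `COc1cccc2c1c(NS(=O)(=O)c1ccc(Cl)c(Cl)c1)nn2Cc1cccc(CNC(=O)C(C)(C)O)c1` gives 76 ug/mL as a measured number.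

Going by the values given here, compound 3 holds the only true number of the three, since the other two values are limits. The next compound to be tested is compound 4 `COc1cccc2c1c(NS(=O)(=O)c1cccc(Cl)c1)nn2Cc1cccc(CNC(=O)C(C)(C)O)c1`, which has hydrogen in place of chloro on an aromatic carbon. The carbon in question is ortho to a chloro group and para to a large group, so 3,4-dichlorophenyl becomes 3-chlorophenyl. Among the compounds with values here, no two measured compounds differ in one place only, so the data give no direct size for this change. Within the data shown here, the starting point is therefore compound 3 at 76 ug/mL as the single number available in this assay. A modest upward move is expected, and it may not clear the usual scatter. The expected step is a 1.4-fold higher number from compound 3 to compound 4 (0.16 log units; within the scatter) in size. Compound 4 is estimated at 110 ug/mL, with an expected range of 55 ug/mL to 190 ug/mL.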

Compound 4, solubility: >= 198 ug/mL
Compound 4 gave a limit, no number; the forecaster's own chance of this, stated with the estimate: 30%; middle value at least 1.8-fold (0.25 log units) from the limit.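

The first pair differing in one place now exists, so putting hydrogen in place of chloro on this aromatic carbon, ortho to a chloro group and para to a large group, can be read in this assay as an at least 2.6-fold higher number from compound 3 to compound 4 (0.41 log units; beyond the scatter). Compound 4 gives >= 198 ug/mL, which is a limit of the assay and not a number. The full size of the step stays unknown because the reading stops at a limit: the limit of >= 198 ug/mL in this assay, at which 1 of the 4 values shown sits.

From the compounds shown here alone, whether a methyl group, a methoxy group or an amine on this same carbon would read more like hydrogen or more like chloro stays open. Also open, going by these compounds, is what happens when the remaining chloro is replaced by hydrogen as well, which would leave a plain phenyl group on the sulfonyl.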